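The source may report more compounds than this note shows. Statements on the series, on what has been measured and on what is new or still open speak of the compounds shown alone.

Compound 3 `O=C(CN1CCN(c2ccccn2)CC1)Nc1nc2ccccc2[nH]1` gives 40.9% in a functional assay, read by spectrophotometry, with a stated time of 30 min, tested at 25 ug/mL (a lower number here means a weaker effect, a higher number a stronger effect of the compound at the concentration tested), the highest of the three numbers. Compound 1 `O=C(CN1CCN(c2ccccc2)CC1)Nc1nc2ccccc2[nH]1` gives 11.5% in this assay, and compound 2 `O=C(CN1CCN(c2ccccc2F)CC1)Nc1nc2ccccc2[nH]1` gives 18.8% in this assay. The gain came with the ring on the ring nitrogen: a number 29.4 percentage points higher from compound 1 to compound 3 (beyond the scatter) and a number 22.1 percentage points higher from compound 2 to compound 3 (beyond the scatter), while a number 7.3 percentage points higher from compound 1 to compound 2 (within the scatter).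

Compound 4 `COc1ccc(N2CCN(CC(=O)Nc3nc4ccccc4[nH]3)CC2)cc1` differs from compound 3 in one place: 4-methoxyphenyl in place of pyridin-2-yl on an amine nitrogen in a ring. This undoes the change that produced the two gains, returning to a carbon-only ring with a methoxy group; the only measured substituent on such a ring, in the step from compound 1 to compound 2, stayed within the scatter. A drop back toward the level of compound 1 and compound 2 is therefore expected, a number 22.9 percentage points lower from compound 3 to compound 4 (beyond the scatter). Compound 4 is estimated at 18% in this assay, between 8% and 34%.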

Compound 4, a percentage reported as activity, at one concentration (the size of the read-out at that concentration, not a potency): 13.3%
Beside the measured number, compound 4's estimate is 4.7 percentage points above it, and the stated range covers the measured number.
By their numbers in this assay, from the lowest: compounds 1, 4 and 2 (each within the scatter of the next); then compound 3.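

In this assay, the gain held by pyridin-2-yl on this amine nitrogen in a ring does not carry over to 4-methoxyphenyl (a number 27.6 percentage points lower from compound 3 to compound 4 (beyond the scatter)). The 4-methoxyphenyl group instead stays with the other carbon-only rings (a number 5.5 percentage points lower from compound 2 to compound 4 (within the scatter); a number 1.8 percentage points higher from compound 1 to compound 4 (within the scatter)), so neither methoxy nor fluoro on such a ring moves the number beyond the scatter, and only compound 3 stands apart.

No measured evidence here accounts for the gain with pyridin-2-yl. Still open, as far as these compounds go, is whether the gain persists with pyridin-4-yl or pyrimidin-2-yl in this place.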